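The source may report more compounds than this note shows. Statements on the series, on what has been measured and on what is new or still open speak of the compounds shown alone.

Compound 1 `COC(=O)c1cc(C2=C(c3cc(OC)c(OC)c(OC)c3)C(=O)CC2O[SiH2]C(C)(C)C)ccc1OC`: > 100 ug/mL
Compound 2 `COc1ccc(C2=C(c3cc(OC)c(OC)c(OC)c3)C(=O)C(OC(C)=O)C2)cc1O`: < 1 ug/mL
Compound 3 `COc1ccc(C2=C(c3cc(OC)c(OC)c(OC)c3)C(=O)C(O)C2)cc1Cl`: < 1 ug/mL

All three were read in an ADME assay on HT-29 cells (Homo sapiens) for cytotoxicity, read by MTT assay, with a stated time of 72 h; on this read-out higher numbers stand for weaker inhibition and lower numbers for stronger inhibition. Compound 1 gives > 100 ug/mL in this assay, which is a limit of the assay and not a number. Compound 2 gives < 1 ug/mL, again a limit. Compound 3 gives < 1 ug/mL, also a limit. Two of the three values therefore sit at the limit of < 1 ug/mL in this assay, at which 2 of the 3 values shown sit, and one at the limit of > 100 ug/mL in this assay, at which 1 of the 3 values shown sits, and compound 1 stands at the weak end of what the set covers. Within the data shown here, no two measured compounds differ in one place, so no measured step exists.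

Compound 4 `COc1ccc(C2=C(c3cc(OC)c(OC)c(OC)c3)C(=O)CC2O[SiH2]C(C)(C)C)cc1O` is compound 1 with hydroxy in place of methoxycarbonyl on an aromatic carbon. The step of an at least 20-fold lower number from compound 1 to compound 4 (1.30 log units; beyond the scatter) is expected to run toward stronger inhibition and beyond the scatter. Compound 4 is estimated at 5 ug/mL, with a range from 1 ug/mL to 30 ug/mL.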

Compound 4, half-maximal inhibitory concentration: 38 ug/mL
The estimate for compound 4 lay 7.6-fold (0.88 log units) below the measured number, outside the stated range (above it).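

In this assay, hydroxy in place of methoxycarbonyl on this aromatic carbon, with the rest of the core of compound 1 unchanged, gives an at least 2.6-fold lower number from compound 1 to compound 4 (0.42 log units; beyond the scatter). Among these compounds, this is the first evidence that this position alone can shift the read-out. The true size of the step remains unknown, as the value for compound 1 is a limit of the assay: the limit of > 100 ug/mL in this assay, at which 1 of the 4 values shown sits.

From the compounds shown here alone, whether an amine or a carboxylic acid at this position would give a different result remains open. So does whether the same change would act similarly on the cores of compound 2 and compound 3.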